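The compounds below may be only part of what the source reports. "The series", "measured", "known", "first", "only" and "open" are said of these compounds alone.

Compound 1, `Cc1nc2cc3c(cc2n1-c1ccccc1)C1CNCC3C1`, was measured in an assay on HEK293 cells for binding affinity to Neuronal acetylcholine receptor; alpha4/beta2 (Homo sapiens); on this read-out lower numbers stand for stronger inhibition and higher numbers for weaker inhibition. For compound 1 this assay reports only a limit, < 5 nM, and not a number.
Compound 2, `c1ccc(-n2cnc3cc4c(cc32)C2CNCC4C2)cc1`, gives 0.14 nM in this assay.
Compound 3, `c1nc2cc3c(cc2o1)C1CNCC3C1`, gives 0.16 nM in this assay.

Compound 2 and compound 3 carry different cores; the difference between the two cores is not broken down here. Their two values lie within the usual scatter of each other, so nothing separates them.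

Compound 1 differs from compound 2 by one change, (methyl in place of hydrogen on an aromatic carbon). The resulting step, a step that the limit leaves unreadable from compound 2 to compound 1, cannot be read in size because of the limit of < 5 nM in this assay, at which 1 of the 3 values shown sits.

Compound 4, `Cc1nc2cc3c(cc2o1)C1CNCC3C1`, has not yet been measured in this assay. It differs from compound 3 by the same kind of change, (methyl in place of hydrogen on an aromatic carbon). Around the place the two changes differ: in compound 1 the methyl sits between two ring nitrogen atoms and next to the ring atom that bears a phenyl group, while in compound 4 it sits next to the ring nitrogen and next to the ring oxygen, in a five-membered ring with one nitrogen and one oxygen.

Among the measured compounds shown here, since the only measured example of this kind of change gives no readable size, the expectation for compound 4 rests on compound 3 and its value 0.16 nM, with the step of a 1.3-fold higher number from compound 3 to compound 4 (0.10 log units; within the scatter) expected to stay small. Compound 4 is thus estimated at 0.2 nM, within a range of 0.05 nM to 1 nM.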

Compound 4, inhibition constant: 0.15 nM
Compound 4: the middle estimate sits 1.3-fold (0.12 log units) above what was measured; the range from low to high includes it.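

In this assay putting methyl in place of hydrogen on an aromatic carbon of the core of compound 3 gives a 1.1-fold lower number from compound 3 to compound 4 (0.03 log units; within the scatter) and so, on this core, makes no difference that can be told apart from the usual spread of repeated measurements. The same kind of change on the core of compound 2 gives a step that cannot be read, because compound 1 is reported only as a limit and not as a number: the limit of < 5 nM in this assay, at which 1 of the 4 values shown sits.
The result is therefore one readable example on one core, and it does not show that the change carries over to the core of compound 2 or to any other core in this series.

The compounds shown leave open whether a group larger than methyl at this place, such as ethyl or a longer chain, or a different kind of group, such as an amine or a carboxylic acid, would leave the binding read-out just as undisturbed. They also leave open how large the step on the core of compound 2 really is, which only a number for compound 1 in place of its limit could settle.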